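Replacing Hydroxy with tert-Butyl on a Saturated Ring Carbon

The source may hold more compounds than are shown below. What is called first, only, known or untested is meant among the compounds shown, and "the series" means these compounds.

Three compounds sharing one core have been measured in an assay on CHO-K1 cells for activation of DNA damage-inducible transcript 3 protein (Homo sapiens), read by a luciferase reporter; a lower number here means that less compound is needed, a higher number that more compound is needed for the effect:

compound 1, `CC1CN(S(=O)(=O)c2ccc(NC(=O)c3ccc([N+](=O)[O-])o3)cc2)CC(C)O1`: 1400 nM
compound 2, `O=C(Nc1ccc(S(=O)(=O)N2CCC(O)CC2)cc1)c1ccc([N+](=O)[O-])o1`: 2000 nM
compound 3, `CC1CCN(S(=O)(=O)c2ccc(NC(=O)c3ccc([N+](=O)[O-])o3)cc2)CC1`: 700 nM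

Compound 2 gives the highest number of the three in this assay. Its gap to compound 1 is small, a 1.4-fold higher number from compound 1 to compound 2 (0.15 log units; within the scatter). Its gap to compound 3 is larger, a 2.9-fold lower number from compound 2 to compound 3 (0.46 log units; beyond the scatter), a modest change that goes beyond the scatter.

Compound 4, `CC(C)(C)C1CCN(S(=O)(=O)c2ccc(NC(=O)c3ccc([N+](=O)[O-])o3)cc2)CC1`, has not yet been measured. It differs from compound 2 in one place: tert-butyl in place of hydroxy on a saturated ring carbon. Within the data shown here, the only measured step that bears on this change is the one to compound 3, a 2.9-fold lower number from compound 2 to compound 3 (0.46 log units; beyond the scatter), where the hydroxy was also removed from the same saturated ring carbon and a carbon group took its place. The step of a 2.0-fold lower number from compound 1 to compound 3 (0.30 log units; within the scatter), which also puts a methyl on that ring, stays within the scatter, so it adds little. With a larger carbon group entering, a lowering of similar size is the natural expectation, a 3.3-fold lower number from compound 2 to compound 4 (0.52 log units; beyond the scatter). Compound 4 is therefore estimated at 600 nM, with a range from 250 nM to 1500 nM.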

Compound 4, concentration for half-maximal activity: 700 nM
Estimate against measurement, compound 4: 1.2-fold (0.07 log units) below; the measured number falls inside the stated range.
By their numbers in this assay, from the lowest: compounds 3, 4, 1 and 2 (each within the scatter of the next, the first and the last beyond it).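

In this assay, tert-butyl in place of hydroxy gives a 2.9-fold lower number from compound 2 to compound 4 (0.46 log units; beyond the scatter) and so shows that the lower number seen with methyl holds on this saturated ring carbon even when a much larger carbon group enters. The two carbon groups cannot be told apart, with no change at the digits printed from compound 3 to compound 4 (within the scatter) for tert-butyl in place of methyl, and 4-(tert-butyl)piperidin-1-yl in place of 2,6-dimethylmorpholin-4-yl on the sulfonyl sulfur likewise gives a 2.0-fold lower number from compound 1 to compound 4 (0.30 log units; within the scatter) as its step. Nothing available here explains why the numbers fall as they do.

On these data alone, it remains open where an amine or a carboxylic acid on this ring carbon would fall. Also open, as far as these compounds go, is whether plain piperidin-1-yl, with only hydrogen there, would sit with hydroxy or with the carbon groups.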